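Swapping a Ring Substituent on a Hydroxamic Acid Chain

The source may report more compounds than this note shows. Statements on the series, on what has been measured and on what is new or still open speak of the compounds shown alone.

Compound 1 `O=C(CCC1=CCN(CCCc2ccc(Br)cc2)C1=O)NO` is examined in a functional assay on ACHN cells (Homo sapiens) for inhibition, read by sulforhodamine B assay (a higher number here means a weaker inhibitor of growth, a lower number a stronger inhibitor of growth), where compound 1 gives 3330 nM. Two neighbours have been measured: compound 2 `Cc1ccc(CN2CC=C(CCC(=O)NO)C2=O)cc1` gives 3330 nM, and compound 3 `CC(C)(C)c1ccc(CCCN2CC=C(CCC(=O)NO)C2=O)cc1` gives 3330 nM, so compound 1 stands level with both at the digits shown, within the scatter. The step of no change at the digits printed from compound 1 to compound 3 (within the scatter) shows that changing the group on the aromatic carbon left the growth inhibition unchanged. Compound 4 `Cc1cccc(CCCN2CC=C(CCC(=O)NO)C2=O)c1` differs from compound 1 by 3-methylphenyl in place of 4-bromophenyl on a saturated chain carbon, three bonds along the chain from an amide-type nitrogen in a ring. Because no change at the digits printed from compound 1 to compound 3 (within the scatter) stayed within the scatter, no step beyond the scatter is expected here either. The expected step is no change at the digits printed from compound 1 to compound 4 (within the scatter). Compound 4 is therefore estimated to give 3330 nM, with a range from 1500 nM to 7500 nM.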

Compound 4, concentration for 50% growth inhibition: 3330 nM
Compound 4: middle estimate and measured number agree at the digits printed; low and high end bracket the measured number.
By their numbers in this assay, from the lowest: compounds 1, 2, 3 and 4 (each within the scatter of the next).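

Replacing 4-bromophenyl with 3-methylphenyl on this saturated chain carbon gives no change at the digits printed from compound 1 to compound 4 (within the scatter) in this assay. The earlier step exchanged only the group on an aromatic carbon, whereas this one alters both the group and the ring position named for it, and the result still stays within the scatter. Nothing measured here offers an explanation for this result. The compounds shown leave open whether an amine or a carboxylic acid on the phenyl ring, or a longer chain, would give a different number.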